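Cyano for methoxy on the triazole-linked phenyl ring

The source may report more compounds than this note shows. Statements on the series, on what has been measured and on what is new or still open speak of the compounds shown alone.

Compound 3 (`COc1ccc(-n2cc(COc3c(/C=C\C(=O)O)ccc(OC)c3CC=C(C)C)nn2)cc1`) gives "not determined" (no result reported) in a functional assay on COLO 205 cells (Homo sapiens) for cytotoxicity, read by MTT assay, with a stated time of 24 h (a higher number here means a weaker inhibitor, a lower number a stronger inhibitor), that is, no reported result; nothing is known of where it stands. Its two measured relatives carry the same core with a different phenyl substituent: compound 1 (`COc1ccc(/C=C\C(=O)O)c(OCc2cn(-c3ccccc3F)nn2)c1CC=C(C)C`) gives 14500 nM in this assay, and compound 2 (`COc1ccc(/C=C\C(=O)O)c(OCc2cn(-c3ccccc3)nn2)c1CC=C(C)C`) gives 32300 nM. Among the compounds with values here, the one step between them, a 2.2-fold higher number from compound 1 to compound 2 (0.35 log units; beyond the scatter), is the only measured change on this phenyl ring, and it is modest.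

Compound 4 (`COc1ccc(/C=C\C(=O)O)c(OCc2cn(-c3ccc(C#N)cc3)nn2)c1CC=C(C)C`) differs from compound 3 by cyano in place of methoxy on an aromatic carbon. The step from compound 1 to compound 2 bears on it only loosely, since it concerns a different group at a different place on the ring; it suggests that substituent changes on this phenyl move this assay by modest amounts. With no number for compound 3, the expectation for compound 4 must rest on compounds 1 and 2 alone, and a value within their neighbourhood is the most that can be said. Compound 4 is therefore estimated at 20000 nM in this assay, with a range from 5000 nM to 80000 nM.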

Compound 4, half-maximal inhibitory concentration: 32000 nM
For compound 4 the middle estimate is 1.6-fold (0.20 log units) below the measured one; low and high end bracket the measured number.
By their numbers in this assay, from the lowest: compound 1; then compounds 4 and 2 (each within the scatter of the next).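

In this assay the step with cyano in place of hydrogen is a 1.0-fold lower number from compound 2 to compound 4 (0.00 log units; within the scatter) and so gives no separation between the 4-cyanophenyl and the unsubstituted phenyl ring. Set against the 2-fluorophenyl ring, the change reads as a 2.2-fold higher number from compound 1 to compound 4 (0.34 log units; beyond the scatter) and is modest, so among these compounds only compound 1 stands apart. The step between compound 3 and compound 4 cannot be read, as compound 3 has no result, and no measurement given here accounts for these numbers.

The compounds shown leave open where the 4-methoxyphenyl ring stands and whether the separation of compound 1 belongs to fluoro itself. They also leave open whether an amine or a trifluoromethyl group on this phenyl ring would move the number any further.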